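A few compounds are considered here, and "the series" means these few. Any claim that something is new, unique, unknown or untested is made for them only; others in the source may bear on it.

Measured compounds in an assay on isolated protein for inhibition of Calpain-1 catalytic subunit (Homo sapiens); a higher number here means a weaker inhibitor, a lower number a stronger inhibitor:
- compound 1 `CCC(NC(=O)C(CC(C)C)NC(=O)OCc1ccccc1)C(=O)C(=O)NCC1CCCCC1`: 680 nM
- compound 2 `CCC(NC(=O)C(CC(C)C)NC(=O)OCc1ccccc1)C(=O)C(=O)NCc1cc(OC)cc(OC)c1`: 2300 nM

Among the compounds with values here, compound 2 stands at the highest of the two numbers recorded in this assay; its only neighbour is compound 1, and the step of a 3.4-fold higher number from compound 1 to compound 2 (0.53 log units; beyond the scatter) lies beyond the scatter. Compound 3 `CCC(NC(=O)C(CC(C)C)NC(=O)OCc1ccccc1)C(=O)C(=O)NCCCN1CCCc2ccccc21` is not yet measured. It differs from compound 2 by 2-(1,2,3,4-tetrahydroquinolin-1-yl)ethyl in place of 3,5-dimethoxyphenyl on a saturated chain carbon bound to an amide-type nitrogen. Within the data shown here, the single measured step that bears on this position is a 3.4-fold higher number from compound 1 to compound 2 (0.53 log units; beyond the scatter), where the aromatic group gave a modestly higher number than the saturated ring. Among the measured compounds shown here, the group entering in compound 3 carries both a saturated ring and an aromatic ring, placed further out on a two-carbon chain; no measured pair tells how such a chain behaves here. A step back toward compound 1 of moderate size is therefore expected, with wide uncertainty. Compound 3 is estimated at 1200 nM, range 300 nM to 5000 nM, which means an expected step of a 1.9-fold lower number from compound 2 to compound 3 (0.28 log units; within the scatter).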

Compound 3, inhibition constant: 370 nM
For compound 3 the middle estimate is 3.2-fold (0.51 log units) above the measured one, within the range that was stated.
By their numbers in this assay, from the lowest: compounds 3 and 1 (each within the scatter of the next); then compound 2.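

In this assay, the position on a saturated chain carbon bound to an amide-type nitrogen accepts a group with two rings: 2-(1,2,3,4-tetrahydroquinolin-1-yl)ethyl in place of 3,5-dimethoxyphenyl gives a 6.2-fold lower number from compound 2 to compound 3 (0.79 log units; beyond the scatter). Set against cyclohexyl, the same group gives a 1.8-fold lower number from compound 1 to compound 3 (0.26 log units; within the scatter), so compound 3 and compound 1 cannot be ordered, and a six-membered aromatic ring of carbon only, present in both compound 2 and compound 3, does not by itself go with the higher number of compound 2. No measurement at hand accounts for these steps.

The compounds shown do not separate the contribution of the two-carbon chain from that of the ring system, which a plain phenyl on the same chain or a longer chain could test. From the compounds shown here alone, the role of the two methoxy groups of compound 2 also stays open, and an unsubstituted phenyl in their place would address it.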